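The source may report more compounds than this note shows. Statements on the series, on what has been measured and on what is new or still open speak of the compounds shown alone.

Working notes on the series. Compound 1 `Cn1cc(-c2cc(C(C)(C)O)ccc2OC2CC2)c2cc(C(=O)NCCCCCCC(=O)NO)[nH]c2c1=O` gives 220 nM in a functional assay on MV4-11 cells (Homo sapiens) for antiproliferative activity, read by CCK-8 assay, with a stated time of 72 h (on this read-out lower numbers stand for stronger inhibition and higher numbers for weaker inhibition), and stands lowest of the three numbers, though within the scatter of both others. Compound 2 `Cn1cc(-c2ccccc2Oc2ccccc2)c2cc(C(=O)NCCCCC(=O)Nc3ccccc3N)[nH]c2c1=O` gives 240 nM in this assay; compound 3 `Cn1cc(-c2cc(C(C)(C)O)ccc2OC2CC2)c2cc(C(=O)NCc3ccc(C(=O)NO)cc3)[nH]c2c1=O` gives 420 nM. Among the compounds with values here, the only single-point step, a 1.9-fold higher number from compound 1 to compound 3 (0.28 log units; within the scatter), concerns the chain and not the ether. Compound 4 `Cc1cc(F)cc(C)c1Oc1ccc(C(C)(C)O)cc1-c1cn(C)c(=O)c2[nH]c(C(=O)NCCCCCCC(=O)NO)cc12` differs from compound 1 at the ether: 4-fluoro-2,6-dimethylphenyl in place of cyclopropyl on an oxygen on an aromatic ring. Within the data shown here, no measured step bears on this change; compounds 1 and 2, cyclopropyloxy against phenoxy with different tails, show near-identical values. Compound 4 is therefore expected to sit within the scatter of compound 1, step a 1.0-fold lower number from compound 1 to compound 4 (0.02 log units; within the scatter), estimated at 210 nM, range 70 nM to 650 nM.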

Compound 4, half-maximal inhibitory concentration: 300 nM
Estimate against measurement, compound 4: 1.4-fold (0.15 log units) below; low and high end bracket the measured number.
By their numbers in this assay, from the lowest: compounds 1, 2, 4 and 3 (each within the scatter of the next).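

Within the data shown here, the step of a 1.4-fold higher number from compound 1 to compound 4 (0.13 log units; within the scatter) gives the first direct reading at this ether: on an oxygen on an aromatic ring, 4-fluoro-2,6-dimethylphenyl, with 9 heavy atoms, replaces cyclopropyl, with 3, and this assay shows no change beyond the scatter. The tail and the rest of the core stay as in compound 1, so the reading belongs to this change alone. No supporting measurement bears on this result.

Going by these compounds, whether a methyl or a 2-aminoethyl group on this oxygen would also stay within the scatter remains open. So does whether 4-fluoro-2,6-dimethylphenyl behaves the same way with the 4-(hydroxycarbamoyl)phenyl tail of compound 3.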